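The source may hold more compounds than are shown below. What is called first, only, known or untested is meant among the compounds shown, and "the series" means these compounds.

Compound 1 `C=C1C[C@]23C[C@@]1(O)CC[C@H]2c1ccc(O)c(C)c1[C@@H]3Cn1cc(-c2ccc(Br)cc2)nn1`: > 20000 nM in a functional assay on SW480 cells (Homo sapiens) for cytotoxicity, read by MTT assay, with a stated time of 4 days (on this read-out higher numbers stand for weaker inhibition and lower numbers for stronger inhibition), a limit.
Compound 2 `C=C1C[C@]23C[C@@]1(O)CC[C@H]2c1ccc(OS(=O)(=O)c2ccc(C)cc2)c(C)c1[C@@H]3Cn1cc(-c2ccc(F)cc2)nn1`: > 20000 nM, a limit.
Compound 3 `C=C1C[C@]23C[C@@]1(O)CC[C@H]2c1ccc(O)c(C)c1[C@@H]3Cn1cc(-c2ccccc2)nn1`: > 20000 nM, a limit.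

Compound 3 stands at the limit of this assay, where every measured value sits (the limit of > 20000 nM in this assay, at which 3 of the 3 values shown sit). Compound 4 `C=C1C[C@]23C[C@@]1(O)CC[C@H]2c1ccc(O)c(C)c1[C@@H]3Cn1cc(-c2ccc(F)cc2)nn1` differs from compound 3 by fluoro in place of hydrogen on an aromatic carbon. Among the measured compounds shown here, the one measured step on the same part of the molecule, a step that the two limits leave unreadable from compound 1 to compound 3, cannot be read because both ends sit at the limit (the limit of > 20000 nM in this assay, at which 3 of the 3 values shown sit). Compound 2 carries the same 4-fluorophenyl group but differs elsewhere, and its value shows only that it, too, stayed at the limit. No step beyond the scatter is therefore expected. Compound 4 is expected at 30000 nM, between 15000 nM and 100000 nM, most likely reported again only as a limit. The expected step this implies is a step that the limit leaves unreadable from compound 3 to compound 4.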

Compound 4, half-maximal inhibitory concentration: > 20000 nM
Compound 4 ended at the assay's limit (the forecaster's own chance of this, stated with the estimate: 85%); the middle value lies beyond the limit too.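

No step can be read between compound 4 and compounds 1, 2 and 3, because all four sit at the same limit: the limit of > 20000 nM in this assay, at which 4 of the 4 values shown sit. What these compounds leave open is whether any change to the shared core would give a real number in this assay rather than a limit.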